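The source may report more compounds than this note shows. Statements on the series, on what has been measured and on what is new or still open speak of the compounds shown alone.

Three compounds share one core and differ only in the group carried by the amine nitrogen of the ring, and all three were measured in an assay on U2OS cells for inhibition of secreted frizzled-related protein 1 (Homo sapiens), read by a luciferase reporter, with a stated time of 18 h; on this read-out lower numbers stand for an effect already at smaller amounts and higher numbers for an effect only at larger amounts of compound. Compound 1 `O=C(c1ccc(C(F)(F)F)cc1)N1CCC(NS(=O)(=O)c2cc(S(=O)(=O)c3ccccc3)ccc2C(F)(F)F)CC1` gives 970 nM in this assay, the highest of the three numbers. Compound 2 `O=S(=O)(NC1CCN(S(=O)(=O)c2ccccc2)CC1)c1cc(S(=O)(=O)c2ccccc2)ccc1C(F)(F)F` gives 210 nM, and compound 3 `N#Cc1cccc(S(=O)(=O)N2CCC(NS(=O)(=O)c3cc(S(=O)(=O)c4ccccc4)ccc3C(F)(F)F)CC2)c1` gives 170 nM. Both changes made at that ring nitrogen moved the number beyond the scatter: a 4.6-fold lower number from compound 1 to compound 2 (0.66 log units; beyond the scatter) and a 5.7-fold lower number from compound 1 to compound 3 (0.76 log units; beyond the scatter). Between compound 2 and compound 3 the step is a 1.2-fold lower number from compound 2 to compound 3 (0.09 log units; within the scatter), so the nitrile makes no difference that can be resolved.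

Compound 4 `CC(C)(C)OC(=O)N1CCC[C@@H]1C(=O)N1CCC(NS(=O)(=O)c2cc(S(=O)(=O)c3ccccc3)ccc2C(F)(F)F)CC1` keeps the carbonyl on the ring nitrogen but changes what sits on it: 1-(tert-butoxycarbonyl)pyrrolidin-2-yl in place of 4-(trifluoromethyl)phenyl on a carbonyl carbon. Going by the values given here, none of the measured steps makes exactly this change. The steps from compound 1 show that this part of the molecule is where the numbers moved, but in those cases the whole carbonyl was exchanged for a sulfonyl, whereas compound 4 retains the carbonyl and exchanges an aromatic ring for a non-aromatic one with a protecting group. Without a closer precedent, the expectation for compound 4 in this assay is a step no larger than the measured ones, most likely a modest move toward larger amounts, a 1.4-fold higher number from compound 1 to compound 4 (0.16 log units; within the scatter). Compound 4 is therefore estimated at 1400 nM, with a range from 350 nM to 5500 nM.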

Compound 4, half-maximal effective concentration: 210 nM
The estimate for compound 4 lay 6.7-fold (0.82 log units) above the measured number, outside the stated range (below it).
By their numbers in this assay, from the lowest: compounds 3, 2 and 4 (each within the scatter of the next); then compound 1.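

In this assay the lower number does not depend on giving up the carbonyl: keeping it on the ring nitrogen and replacing only the group it carries gives a 4.6-fold lower number from compound 1 to compound 4 (0.66 log units; beyond the scatter) and so matches the size of the step to compound 2, which exchanged the whole carbonyl for a sulfonyl. The earlier steps shown here all made that exchange and removed the 4-(trifluoromethyl)phenyl in the same move, so they could not show which of the two mattered; compound 4 shows that changing the group on the carbonyl is enough for a move of this size. No measurement at hand explains why the number moves with this change.

The entering 1-(tert-butoxycarbonyl)pyrrolidin-2-yl differs from the group it replaces in several ways at once, so the compounds shown do not separate the contributions of the tert-butoxycarbonyl, the five-membered ring and the defined stereocentre. Still open, going by these compounds, are how a pyrrolidin-2-yl with a free amine, its mirror-image form, or a plain phenyl on the same carbonyl would read.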